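Chain-end replacements on the shared core: compounds 1 to 4

The source may report more compounds than this note shows. Statements on the series, on what has been measured and on what is new or still open speak of the compounds shown alone.

Measured so far in a functional assay on H4 cells for agonist activity at growth hormone secretagogue receptor type 1 (Homo sapiens), read by FLIPR; a lower number here means that less compound is needed, a higher number that more compound is needed for the effect:
compound 1 `CC(C)(N)C(=O)N[C@H](COCc1ccccc1)c1nnnn1CCCc1ccccc1`: 17 nM
compound 2 `CN(c1ccccc1CCCn1nnnc1[C@@H](COCc1ccccc1)NC(=O)C(C)(C)N)S(C)(=O)=O`: 14 nM
compound 3 `CC(C)(N)C(=O)N[C@H](COCc1ccccc1)c1nnnn1CCCCCNS(C)(=O)=O`: 75 nM

Compound 3 carries the highest number of the three. The step of a 4.4-fold higher number from compound 1 to compound 3 (0.64 log units; beyond the scatter) and the step of a 5.4-fold higher number from compound 2 to compound 3 (0.73 log units; beyond the scatter) both run toward compound 3, whereas a 1.2-fold lower number from compound 1 to compound 2 (0.08 log units; within the scatter) is flat.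

Compound 4 `CC(C)(N)C(=O)N[C@H](COCc1ccccc1)c1nnnn1CCC#N` is the next step from compound 3: cyano in place of 3-(methanesulfonamido)propyl on a saturated chain carbon, two bonds along the chain from an aromatic nitrogen. For the measured compounds named here, no measured step removes the methanesulfonamido group or shortens the chain this far, so the two steps into compound 3 are only loose guides; they show that the chain end matters by a modest margin, in either direction here unknown. For compound 4 a step of a 1.3-fold higher number from compound 3 to compound 4 (0.12 log units; within the scatter) is expected, with wide uncertainty. Compound 4 is therefore estimated at 100 nM in this assay, range 30 nM to 400 nM.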

Compound 4, half-maximal effective concentration: 30 nM
Beside the measured number, compound 4's estimate is 3.3-fold (0.52 log units) above it, and the stated range covers the measured number.
By their numbers in this assay, from the lowest: compounds 2, 1 and 4 (each within the scatter of the next, the first and the last beyond it); then compound 3.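

In this assay, the step from the long sulfonamide chain to the short nitrile gives a 2.5-fold lower number from compound 3 to compound 4 (0.40 log units; beyond the scatter), so at this position, two bonds along the chain from an aromatic nitrogen, removing the 3-(methanesulfonamido)propyl group does not cost activity. Cyano in place of benzyl gives a 1.8-fold higher number from compound 1 to compound 4 (0.25 log units; within the scatter), which shows that a chain end with no ring can stay level with the aromatic one. No measurement at hand accounts for either step. From the compounds shown here alone, whether a longer chain ending in cyano would follow compound 4 or compound 3 remains open. So does the outcome with an amine or a carboxylic acid at the chain end.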